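The source may report more compounds than this note shows. Statements on the series, on what has been measured and on what is new or still open speak of the compounds shown alone.

In an ADME assay on MT4 cells (Homo sapiens) for inhibition, read by MTT assay, with a stated time of 5 days (on this read-out higher numbers stand for lower toxicity in this test and lower numbers for higher toxicity in this test), compound 1 (`Cc1cc(Br)cc(C)c1Oc1cc(Nc2ccc(C#N)cc2)ncc1[N+](=O)[O-]`) gives 12300 nM and compound 2 (`N#Cc1ccc(Nc2cc(Oc3c(Cl)cc(Cl)cc3Cl)c([N+](=O)[O-])cn2)cc1`) gives 16200 nM. These two compounds share a core and differ only in the group on an oxygen on an aromatic ring. The measured step between them is a 1.3-fold higher number from compound 1 to compound 2 (0.12 log units; within the scatter), which lies within the usual scatter of repeated measurements. On these numbers, compound 2 cannot be told apart from compound 1.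

Compound 3 (`N#Cc1ccc(Nc2cc(Oc3c(F)cc(F)cc3F)c([N+](=O)[O-])cn2)cc1`) has not yet been measured. It keeps the core of compound 2 and changes one group: 2,4,6-trifluorophenyl in place of 2,4,6-trichlorophenyl on an oxygen on an aromatic ring. In words, 2,4,6-trifluorophenyl stands in place of 2,4,6-trichlorophenyl on an oxygen on an aromatic ring.

Going by the values given here, only one measured step bears on this change, the step between compound 1 and compound 2, which altered the group at the same place. Its size gives no reason to expect a step beyond the scatter in this assay, and no direction can be drawn from it, although one step is thin evidence. The expected step is a 1.1-fold lower number from compound 2 to compound 3 (0.03 log units; within the scatter). For compound 3 the estimated value is 15000 nM, with an expected range of 6000 nM to 38000 nM.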

Compound 3, half-maximal cytotoxic concentration: 3540 nM
For compound 3 the middle estimate is 4.2-fold (0.63 log units) above the measured one, and the stated range ends above it.
By their numbers in this assay, from the lowest: compound 3; then compounds 1 and 2 (each within the scatter of the next).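

In this assay, the group on an oxygen on an aromatic ring now proves able to move the number beyond the scatter, which the step between compound 1 and compound 2 did not show: 2,4,6-trifluorophenyl in place of 2,4,6-trichlorophenyl gives a 4.6-fold lower number from compound 2 to compound 3 (0.66 log units; beyond the scatter), and lower numbers here stand for higher toxicity in this test. The two groups match in everything counted here (heavy atoms, ring, hydrogen-bond donors and acceptors, charge) and differ only in carrying fluorine rather than chlorine, and the change from 4-bromo-2,6-dimethylphenyl points the same way, with a 3.5-fold lower number from compound 1 to compound 3 (0.54 log units; beyond the scatter). Nothing available here explains why this one group stands apart from the other two.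

With only three groups shown at this place, it stays open whether the lower number needs all the fluorine atoms of the 2,4,6-trifluorophenyl group or would also appear with a single fluorine or an unsubstituted phenyl. Going by these compounds, how a group of another kind, such as a ring carrying an amine or a carboxylic acid, would behave at this place also stays open.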